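Aryl group change on the amine nitrogen: compound 3

The source may report more compounds than this note shows. Statements on the series, on what has been measured and on what is new or still open speak of the compounds shown alone.

Measured so far:
compound 1 `CC1CCn2c(ncc(C(=O)O)c2=O)/C1=N/Nc1ccccc1`: 5400 nM
compound 2 `CC1CC/C(=N\Nc2ccccc2F)c2ncc(C(=O)O)c(=O)n21`: 1200 nM

Both compounds were run in a functional assay (mast cells) for inhibition, with Rattus norvegicus as the target; on this read-out higher numbers stand for an effect only at larger amounts of compound and lower numbers for an effect already at smaller amounts. Among the measured compounds shown here, compound 2 stands lowest of the two numbers known, and its nearest neighbour, compound 1, lies beyond the scatter at a higher number. For the measured compounds named here, no pair of measured compounds differs in only one place, so no single-change step is known, and the two values show only that compound 2 acts at smaller amounts than compound 1.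

Compound 3 `CC1CC/C(=N\Nc2ccc(O)cc2)c2ncc(C(=O)O)c(=O)n21` is the next compound to be measured in this assay. It differs from compound 2 as follows: 4-hydroxyphenyl in place of 2-fluorophenyl on an amine nitrogen. Going by the values given here, nothing measured so far bears a 4-hydroxyphenyl on that nitrogen, so the effect of this change has no precedent. Compound 3 is therefore expected to stay near compound 2, with a step of a 1.3-fold higher number from compound 2 to compound 3 (0.10 log units; within the scatter) that should not go beyond the scatter, although the range is kept wide. Compound 3 is estimated at 1500 nM, between 400 nM and 6000 nM.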

Compound 3, half-maximal effective concentration: 1300 nM
Estimate against measurement, compound 3: 1.2-fold (0.06 log units) above, and the stated range covers the measured number.
By their numbers in this assay, from the lowest: compounds 2 and 3 (each within the scatter of the next); then compound 1.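

In this assay the series now has its first single-change step, which reads a 1.1-fold higher number from compound 2 to compound 3 (0.03 log units; within the scatter) and places 4-hydroxyphenyl and 2-fluorophenyl on an amine nitrogen within the scatter of each other. At this place, the aryl group can therefore carry a hydrogen-bond donor and a hydrogen-bond acceptor, as 4-hydroxyphenyl does and 2-fluorophenyl does not, with no difference in the read-out that can be distinguished for this pair. No measurement at hand gives a reason for this result.

The two groups differ in both the substituent and its place on the phenyl ring, so this pair cannot separate those two changes, and the absence of a step beyond the scatter could reflect either one or both together. Still open, from the compounds shown here alone, is whether an aminophenyl, a methoxyphenyl, a pyridyl or a benzyl group on the same nitrogen reads alike in this assay, and whether the series holds up when the carboxylic acid of the shared core gives way to an amide or an ester.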